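The compounds below may be only part of what the source reports. "The series", "measured", "known", "first", "only" and "open" are said of these compounds alone.

Measured in a functional assay on MCF7 cells (Homo sapiens) for inhibition, read by MTT assay, with a stated time of 48 h; on this read-out higher numbers stand for weaker inhibition of growth and lower numbers for stronger inhibition of growth:
- compound 1 `Cn1cc(C2CC(c3ccccc3)=NN2C(=O)c2cccnc2)c2ccccc21`: 7200 nM
- compound 2 `COc1ccc(C(=O)N2N=C(c3ccccc3)CC2c2cn(C)c3ccccc23)cn1`: 4310 nM
- compound 3 `Cn1cc(C2CC(c3ccccc3)=NN2C(=O)c2ccncc2)c2ccccc21`: 1110 nM

Compound 1 sits level with compound 2 on these numbers, as a 1.7-fold lower number from compound 1 to compound 2 (0.22 log units; within the scatter) shows. It stands clearly apart from compound 3, with a 6.5-fold lower number from compound 1 to compound 3 (0.81 log units; beyond the scatter). Compound 3 also separates from compound 2, with a 3.9-fold lower number from compound 2 to compound 3 (0.59 log units; beyond the scatter).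

The next compound to be tested is compound 4 `COc1ccc2c(c1)c(C1CC(c3ccccc3)=NN1C(=O)c1cccnc1)cn2C`. It keeps the core of compound 1 and carries one change, methoxy in place of hydrogen on an aromatic carbon, on a six-membered aromatic ring of carbon only, part of a fused or bridged system of two rings.

Among the measured compounds shown here, the closest precedent is the same swap made on the pyridin-3-yl group, which gave a 1.7-fold lower number from compound 1 to compound 2 (0.22 log units; within the scatter). For the measured compounds named here, no measured compound carries a methoxy on the fused system, so this precedent is only indirect. The pyridin-4-yl swap, a 6.5-fold lower number from compound 1 to compound 3 (0.81 log units; beyond the scatter), shows that this series can move beyond the scatter, but it concerns a different part of the molecule.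

A small change in this assay is therefore expected, with none beyond the scatter: the expected step is a 1.4-fold lower number from compound 1 to compound 4 (0.16 log units; within the scatter). For compound 4 the estimated value is 5000 nM, with an expected range of 1700 nM to 13000 nM.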

Compound 4, concentration for 50% growth inhibition: 1160 nM
Compound 4: middle estimate off by 4.3-fold (0.63 log units), on the high side, outside the stated range (below it).
By their numbers in this assay, from the lowest: compounds 3 and 4 (each within the scatter of the next); then compounds 2 and 1 (each within the scatter of the next).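

In this assay, methoxy in place of hydrogen on the six-membered aromatic ring of carbon only, part of a fused or bridged system of two rings, gives a 6.2-fold lower number from compound 1 to compound 4 (0.79 log units; beyond the scatter) and so moves the number beyond the scatter. The same replacement on the pyridin-3-yl group gave a 1.7-fold lower number from compound 1 to compound 2 (0.22 log units; within the scatter) and stayed within the scatter, so in these two cases the outcome of adding a methoxy depends on where it is placed on compound 1. Among the compounds shown here, until now, the only step from compound 1 to pass the scatter was the change at the carbonyl carbon, a 6.5-fold lower number from compound 1 to compound 3 (0.81 log units; beyond the scatter), whereas compound 4 shows that the fused system is also a place where a single change can do so.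

From the compounds shown here alone, whether a hydroxy group, a chlorine atom or a longer chain such as ethoxy at this same carbon would behave like methoxy remains open, as does the outcome of joining this methoxy to the pyridin-4-yl group of compound 3. Nothing given here accounts for why the methoxy counts at this place and not on the pyridin-3-yl group.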